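This account rests on a few compounds, and the source may have more. Where it says the series, first, only, none or still open, it means among the compounds named here.

Measured in an in vitro ADME assay on microsomes from liver (Homo sapiens) for metabolic stability (on this read-out higher numbers stand for fast clearance and lower numbers for slow clearance), so far:

compound 1 `CC(C)NC(=O)[C@H]1CC[C@@H](n2/c(=N/C(=O)c3ccccc3)[nH]c3ccc(CN4CCCCC4)cc32)CC1` gives 203 mL.min-1.g-1
compound 2 `CCNC(=O)[C@H]1CC[C@@H](n2/c(=N/C(=O)c3ccccc3)[nH]c3ccc(CN4CCCCC4)cc32)CC1` gives 194 mL.min-1.g-1
compound 3 `CCN(CC)C(=O)[C@H]1CC[C@@H](n2/c(=N/C(=O)c3ccccc3)[nH]c3ccc(CN4CCCCC4)cc32)CC1` gives 364 mL.min-1.g-1

Compound 3 sits within the scatter of the other two. The steps are a 1.8-fold higher number from compound 1 to compound 3 (0.25 log units; within the scatter) and a 1.9-fold higher number from compound 2 to compound 3 (0.27 log units; within the scatter). Compound 4 `CCOC(=O)[C@H]1CC[C@@H](n2/c(=N/C(=O)c3ccccc3)[nH]c3ccc(CN4CCCCC4)cc32)CC1` differs from compound 3 as follows: ethoxy in place of diethylamino on a carbonyl carbon. All measured changes fall on the same carbonyl carbon, and a 1.0-fold lower number from compound 1 to compound 2 (0.02 log units; within the scatter) is equally small. Within the data shown here, no measured compound carries ethoxy there, so these steps offer only indirect guidance. No step beyond the scatter is therefore expected in this assay. The expected change is a 1.2-fold lower number from compound 3 to compound 4 (0.08 log units; within the scatter). For compound 4 the estimated value is 300 mL.min-1.g-1, with an expected range of 150 mL.min-1.g-1 to 600 mL.min-1.g-1.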

Compound 4, intrinsic clearance in microsomes: 222 mL.min-1.g-1
Estimate against measurement, compound 4: 1.4-fold (0.13 log units) above; low and high end bracket the measured number.
By their numbers in this assay, from the lowest: compounds 2, 1, 4 and 3 (each within the scatter of the next).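

In this assay, ethoxy on the carbonyl carbon gives a 1.6-fold lower number from compound 3 to compound 4 (0.21 log units; within the scatter) against diethylamino, a 1.1-fold higher number from compound 2 to compound 4 (0.06 log units; within the scatter) against ethylamino and a 1.1-fold higher number from compound 1 to compound 4 (0.04 log units; within the scatter) against isopropylamino. The earlier compounds shown here all carried an amide-type nitrogen on this carbon, and compound 4 shows that oxygen there gives no step beyond the scatter against any of them. Nothing measured here speaks to a cause for these numbers. On these data alone, whether a carboxylic acid or a longer chain on the oxygen at this carbonyl carbon would also stay within the scatter remains open.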